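This account rests on a few compounds, and the source may have more. Where it says the series, first, only, none or still open, it means among the compounds named here.

Measured so far:
compound 1 `COc1ccc(-c2ccc(-c3ccc(C(=N)N)o3)o2)cc1`: 2800 nM
compound 2 `COc1cc(OC)cc(-c2ccc(-c3ccc(C(=N)N)o3)o2)c1`: 1950 nM

In a functional assay on SK-MEL-5 cells (Homo sapiens) for inhibition, read by sulforhodamine B assay, with a stated time of 48 h (a lower number here means a stronger inhibitor of growth, a higher number a weaker inhibitor of growth), compound 1 gives 2800 nM, and compound 2 gives 1950 nM; the two sit within the scatter of each other, so compound 1 cannot be separated from compound 2 on these numbers.

Compound 3 `N=C(N)c1ccc(-c2ccc(-c3ccc(F)cc3)o2)o1` differs from compound 1 in one place: fluoro in place of methoxy on an aromatic carbon. Among the compounds with values here, no measured pair shows this change, so the step from compound 1 to compound 3 rests on nothing beyond the shared core. The expected step of a 1.1-fold higher number from compound 1 to compound 3 (0.03 log units; within the scatter) is small, none beyond the scatter in either direction. Compound 3 is estimated at 3000 nM, within 1200 nM to 7500 nM.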

Compound 3, concentration for 50% growth inhibition: 1560 nM
Compound 3: middle estimate off by 1.9-fold (0.28 log units), on the high side; the range from low to high includes it.
By their numbers in this assay, from the lowest: compounds 3, 2 and 1 (each within the scatter of the next).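

On the aromatic carbon para to a large group, fluoro in place of methoxy gives a 1.8-fold lower number from compound 1 to compound 3 (0.25 log units; within the scatter) in this assay, so this one-place change cannot be separated from no change. Across this pair, the position takes either group, with methoxy's carbon and oxygen replaced by a single fluorine, without a step beyond the scatter. No measurement at hand bears on the reason for this result.

Going by these compounds, whether an amine, a carboxylic acid or a longer chain at this place would move the number beyond the scatter stays open. The pair also cannot show whether a different group here would give a stronger or weaker inhibitor of growth than compound 1.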